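The source may report more compounds than this note shows. Statements on the series, on what has been measured and on what is new or still open speak of the compounds shown alone.

Within the data shown here, the shared core carries a hydrazone linker to a substituted phenyl ring, and the series varies only that ring. Compound 1 `Cc1c(C(=O)N/N=C\c2ccccc2F)oc2cccc(O)c12` sets the starting point. In a functional assay on PC-3 cells (Homo sapiens) for inhibition (a lower number here means a stronger inhibitor, a higher number a weaker inhibitor), compound 1 gives >= 40000 nM, which is a limit of the assay rather than a number (the limit of >= 40000 nM in this assay, at which 1 of the 3 values shown sits). Compound 2 `Cc1c(C(=O)N/N=C\c2c(O)cccc2F)oc2cccc(O)c12` differs from it by hydroxy in place of hydrogen on an aromatic carbon, and in this assay compound 2 gives 8050 nM, so that an at least 4.9-fold lower number from compound 1 to compound 2 (0.69 log units; beyond the scatter). Compound 3 `Cc1c(C(=O)N/N=C\c2ccc(O)cc2O)oc2cccc(O)c12` replaces the ring altogether, with 2,4-dihydroxyphenyl in place of 2-fluorophenyl on a carbon with a double bond to nitrogen; in this assay compound 3 gives 14800 nM, and an at least 2.7-fold lower number from compound 1 to compound 3 (0.43 log units; beyond the scatter). Between the two hydroxylated rings, a 1.8-fold higher number from compound 2 to compound 3 (0.26 log units; within the scatter).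

Compound 4 `Cc1c(C(=O)N/N=C\c2ccc(O)c(O)c2O)oc2cccc(O)c12` is not yet measured. Its change from compound 3 is hydroxy in place of hydrogen on an aromatic carbon, the same kind of change as that from compound 1 to compound 2, though the surroundings differ: there the new hydroxy stood ortho to a large group and meta to a fluoro group, here it stands ortho to two hydroxy groups and meta to a large group. Compound 4 is expected to show a 1.9-fold lower number from compound 3 to compound 4 (0.27 log units; within the scatter), a smaller step than the earlier one because an at least 4.9-fold lower number from compound 1 to compound 2 (0.69 log units; beyond the scatter) started from a limit. Compound 4 is estimated at 8000 nM, between 2500 nM and 25000 nM.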

Compound 4, half-maximal inhibitory concentration: >= 40000 nM
Compound 4: no number, only a limit; the forecaster's own chance of this, stated with the estimate: 10%; middle value at least 5.0-fold (0.69 log units) from the limit.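

In this assay compound 4 gives >= 40000 nM, which is a limit of the assay and not a number. Hydroxy in place of hydrogen on an aromatic carbon therefore gives an at least 2.7-fold higher number from compound 3 to compound 4 (0.43 log units; beyond the scatter), so the change does not carry over from one pair to the other in the same direction: the same change on two cores in this assay, an at least 4.9-fold lower number (0.69 log units; beyond the scatter) from compound 1 to compound 2 and an at least 2.7-fold higher number (0.43 log units; beyond the scatter) from compound 3 to compound 4, at least 13-fold (1.12 log units) apart, beyond the scatter of two such steps Across these two pairs, the result of this change depends on the ring that receives it, but two pairs set no rule for the series, and the data show neither why the direction reverses nor how large either step truly is, as each rests on a limit: the limit of >= 40000 nM in this assay, at which 2 of the 4 values shown sit.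

The compounds shown leave open how a methoxy group or an amine would behave in place of the added hydroxy on the ring of compound 3. They also leave open whether a chloro group in place of the fluoro group of compound 2 would keep the value seen with that ring.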